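The source may hold more compounds than are shown below. What is called first, only, known or untested is meant among the compounds shown, and "the series" means these compounds.

Compound 1 `C=CC(=O)N1C(=O)CC(c2ccc(C(=O)OC)cc2)Sc2ccccc21`: 79600 nM
Compound 2 `C=CC(=O)N1C(=O)CC(c2ccc(-c3ccccc3)cc2)Sc2ccccc21`: 97500 nM
Compound 3 `C=CC(=O)N1C(=O)CC(c2ccc(Cl)cc2)Sc2ccccc21`: 82400 nM

These values come from a functional assay on MOLT-4 cells (Homo sapiens) for cytotoxicity, read by CCK-8 assay, with a stated time of 24 h; on this read-out higher numbers stand for weaker inhibition and lower numbers for stronger inhibition. Compound 2 gives the highest of the three numbers, but each gap to the others is within the scatter: a 1.2-fold higher number from compound 1 to compound 2 (0.09 log units; within the scatter) and a 1.2-fold lower number from compound 2 to compound 3 (0.07 log units; within the scatter). Compound 4 `C=CC(=O)N1C(=O)CC(c2ccc(Br)cc2)Sc2ccccc21` has not yet been measured. It differs from compound 2 in one place, (bromo in place of phenyl on an aromatic carbon), the new group standing on an aromatic carbon para to a large group. The closest comparison is the replacement of phenyl by chloro at this carbon, and the two other replacements there, a 1.0-fold higher number from compound 1 to compound 3 (0.02 log units; within the scatter) and a 1.2-fold higher number from compound 1 to compound 2 (0.09 log units; within the scatter), were likewise within the scatter. For compound 4 no step beyond the scatter is therefore expected in this assay, only a 1.1-fold lower number from compound 2 to compound 4 (0.06 log units; within the scatter). Compound 4 is estimated at 85000 nM, within a range from 55000 nM to 130000 nM.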

Compound 4, half-maximal inhibitory concentration: 106000 nM
Compound 4: middle estimate off by 1.2-fold (0.10 log units), on the low side; the range from low to high includes it.
By their numbers in this assay, from the lowest: compounds 1, 3, 2 and 4 (each within the scatter of the next).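

In this assay, bromo on this aromatic carbon, para to a large group, brings no step beyond the scatter against any of the three earlier groups: a 1.1-fold higher number from compound 2 to compound 4 (0.04 log units; within the scatter), a 1.3-fold higher number from compound 3 to compound 4 (0.11 log units; within the scatter) and a 1.3-fold higher number from compound 1 to compound 4 (0.12 log units; within the scatter). Even bromo, with 1 heavy atom, in place of phenyl, with 6, stays within the scatter, so the four compounds show no dependence on the group at this carbon. Nothing measured here offers an explanation for this. Going by these compounds, whether an amine or a carboxylic acid at this carbon would give a step beyond the scatter remains open. So does whether changes elsewhere on the shared core would do so.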